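The source may report more compounds than this note shows. Statements on the series, on what has been measured and on what is new or still open speak of the compounds shown alone.

Measured so far in an ADME assay on MT4 cells (Homo sapiens) for cytotoxicity, read by MTT assay, with a stated time of 4 days; a higher number here means that more compound is tolerated, a lower number that less compound is tolerated:
compound 1 `C/C(=N\NC(=O)COc1cccc2ccccc12)c1cccc([N+](=O)[O-])c1` gives 12.1 ug/mL
compound 2 `COc1ccc(/C=N/NC(=O)COc2cccc3ccccc23)cc1O` gives 7.05 ug/mL
compound 3 `COc1ccc(/C=N/NC(=O)COc2cccc3ccccc23)cc1OC` gives 14.7 ug/mL

Compound 1 stands within the scatter of both compound 2 and compound 3, while those two are separated by a measured step beyond the scatter (a 2.1-fold higher number from compound 2 to compound 3 (0.32 log units; beyond the scatter)). Still to be measured is compound 4 `C/C(=N\NC(=O)COc1cccc2ccccc12)c1ccccc1O`, which differs from compound 1 by 2-hydroxyphenyl in place of 3-nitrophenyl on a carbon with a double bond to nitrogen. For the measured compounds named here, no measured pair makes this change. Going by the values given here, the one step available bears on it only partly. That step is methyl in place of hydrogen on an oxygen on an aromatic ring, and it is modest, with the lower number on the side that keeps the hydrogen, compound 2 (7.05 ug/mL). Compound 4 also carries such a hydrogen, on its 2-hydroxyphenyl. A small shift toward a lower number is therefore expected in this assay, no larger than that modest step and perhaps not clear of the scatter. The expected change is small (a 1.6-fold lower number from compound 1 to compound 4 (0.21 log units; within the scatter)). For compound 4 the estimate is 7.5 ug/mL, with an expected range from 2.5 ug/mL to 22 ug/mL.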

Compound 4, half-maximal cytotoxic concentration: 11.3 ug/mL
For compound 4 the middle estimate is 1.5-fold (0.18 log units) below the measured one, and the stated range covers the measured number.
By their numbers in this assay, from the lowest: compounds 2, 4, 1 and 3 (each within the scatter of the next, the first and the last beyond it).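

For the compounds shown here, putting 2-hydroxyphenyl in place of 3-nitrophenyl on a carbon with a double bond to nitrogen gives a 1.1-fold lower number from compound 1 to compound 4 (0.03 log units; within the scatter) in this assay and so offers the first reading at this position, where a change of ring substituents leaves the number within the scatter. The hydrogen on an oxygen on an aromatic ring, the point of difference in a 2.1-fold higher number from compound 2 to compound 3 (0.32 log units; beyond the scatter), does not mark out a lower number here: compound 4 carries such a hydrogen and still stands within the scatter of compound 1. Nothing available explains why this position reads flat in this change.

The nitro group leaves and the hydroxyl enters in one step, so the compounds shown do not separate the contribution of either group, and an unsubstituted phenyl at this place would be the natural reference. They also leave open how this position responds to groups of another kind, such as an aminophenyl, a phenyl bearing a carboxylic acid, or a longer chain in place of the saturated chain carbon.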